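The source may report more compounds than this note shows. Statements on the series, on what has been measured and on what is new or still open speak of the compounds shown alone.

Working notes on the series. Among the measured compounds shown here, compound 1 `COC(=O)c1ccc(N(Cc2cnc(C3CCCCC3)cn2)C(=O)[C@H]2CCN2S(=O)(=O)c2c(F)c(F)c(F)c(F)c2F)c(F)c1` is the only member with a number so far: in a functional assay on MCF7 cells (Homo sapiens) for antiproliferative activity, with a stated time of 72 h (a higher number here means that more compound is needed for the effect, a lower number that less compound is needed), compound 1 gives 8900 nM. For the measured compounds named here, compound 2 `NC(=O)c1ccc(N(Cc2ccc(C3CCCCC3)cn2)C(=O)[C@H]2CCN2S(=O)(=O)c2c(F)c(F)c(F)c(F)c2F)c(F)c1` was submitted to this assay, where compound 2 gives "not determined" (no result reported), so compound 2 stands without a number and nothing can be said of how it compares with compound 1; the two also differ from each other in more than one place, so no single step connects them. Compound 3 `O=C1NC(=O)c2cc(N(Cc3ccc(C4CCCCC4)cn3)C(=O)[C@H]3CCN3S(=O)(=O)c3c(F)c(F)c(F)c(F)c3F)ccc21` is the next member to be measured in this assay. It differs from compound 2 by a group of 11 heavy atoms (8 carbon, 1 nitrogen, 2 oxygen; one five-membered non-aromatic ring with 1 hetero atom, one six-membered aromatic ring of carbon only) in place of a group of 10 heavy atoms (7 carbon, 1 nitrogen, 1 oxygen, 1 fluorine; one six-membered aromatic ring of carbon only), on an amide-type nitrogen. Going by the values given here, with compound 2 lacking a value, no step can be read off for this change, and no comparable step exists elsewhere; the direction of any shift from compound 2 to compound 3 is therefore open, and a shift no larger than the usual scatter is as plausible as one in either direction. Anchoring on compound 1 as the only measured point, compound 3 is expected to give roughly 6000 nM in this assay, within an estimated range from 800 nM to 40000 nM.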

Compound 3, half-maximal effective concentration: 7000 nM
Estimate against measurement, compound 3: 1.2-fold (0.07 log units) below; low and high end bracket the measured number.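

No new step can be read in this assay: compound 2 carries no number, and compound 3 has no partner with a value that differs from it in one place. The compounds shown leave open how exchanging the 4-carbamoyl-2-fluorophenyl group of compound 2 for the group in compound 3 shifts the read-out. No evidence bears on this result.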